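Cytotoxicity notes: hydroxy to methoxy from compound 3

The source may report more compounds than this note shows. Statements on the series, on what has been measured and on what is new or still open speak of the compounds shown alone.

Three members of the shared core have been run in an ADME assay on RAW264.7 cells (Mus musculus) for cytotoxicity, read by MTT assay, with a stated time of 24 h; on this read-out higher numbers stand for lower toxicity in this test and lower numbers for higher toxicity in this test: compound 1 `COc1ccccc1C(=O)Nc1ccc(Cl)cc1F`, compound 2 `O=c1oc2ccccc2c(=O)n1-c1ccc(Cl)cc1F` and compound 3 `COc1ccc(C(=O)Nc2ccc(Cl)cc2F)c(O)c1`. Compound 1 reaches only a limit of this assay, > 40000 nM, not a number. Compound 2 gives 26500 nM. Compound 3 gives 32300 nM, which stands as the higher of the two numbers shown, though its gap to compound 2 lies within the scatter, so no ordering of the two is claimed. Compound 4 `COc1ccc(C(=O)Nc2ccc(Cl)cc2F)c(OC)c1` is not yet measured; it differs from compound 3 by methyl in place of hydrogen on an oxygen on an aromatic ring. Among the measured compounds shown here, no measured step of this kind exists, so the expected change from compound 3 to compound 4 is none beyond the scatter, a 1.0-fold higher number from compound 3 to compound 4 (0.01 log units; within the scatter). Compound 4 is accordingly estimated at 33000 nM, with a range of 15000 nM to 50000 nM in this assay, with a fair chance that only a limit is returned.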

Compound 4, half-maximal cytotoxic concentration: 13600 nM
For compound 4 the middle estimate is 2.4-fold (0.38 log units) above the measured one; measured number outside the range, below it.
By their numbers in this assay, from the lowest: compounds 4, 2 and 3 (each within the scatter of the next, the first and the last beyond it). At a limit, above all of these: compound 1.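

In this assay, among the compounds shown here, methyl on the oxygen on an aromatic ring gives the first measured step at this place, towards higher toxicity in this test: a 2.4-fold lower number from compound 3 to compound 4 (0.38 log units; beyond the scatter). Methoxy in place of hydrogen on an aromatic carbon gives an at least 2.9-fold lower number from compound 1 to compound 4 (0.46 log units; beyond the scatter). Compound 1 stands at a limit, so this second step gives only a bound: the limit of > 40000 nM in this assay, at which 1 of the 4 values shown sits.

The compounds shown leave open whether this shift belongs to methyl alone or to any group on that oxygen. An ethyl group or a longer chain there would separate the two readings.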